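From a Difluorophenyl to a Nitrophenyl Arm

A few compounds are considered here, and "the series" means these few. Any claim that something is new, unique, unknown or untested is made for them only; others in the source may bear on it.

Three measured compounds share one core and differ only in the ring at the far end of a double-bonded chain. Compound 1 `COc1ccc(C(=O)c2cc(OC)c(OC)c(OC)c2)cc1NC(=O)/C=C/c1ccc(OC)c(OC)c1` gives 8200 nM in a functional assay on COLO 205 cells (Homo sapiens) for cytotoxicity, read by MTT assay, with a stated time of 72 h; on this read-out higher numbers stand for weaker inhibition and lower numbers for stronger inhibition. Compound 2 `COc1cc(/C=C/C(=O)Nc2cc(C(=O)c3cc(OC)c(OC)c(OC)c3)ccc2OC)ccc1F` gives 11800 nM in this assay, and compound 3 `COc1ccc(C(=O)c2cc(OC)c(OC)c(OC)c2)cc1NC(=O)/C=C/c1ccc(F)c(F)c1` gives 6020 nM in this assay. Compound 3 sits at the low end of these three numbers, yet its gaps to the others, a 1.4-fold lower number from compound 1 to compound 3 (0.13 log units; within the scatter) and a 2.0-fold lower number from compound 2 to compound 3 (0.29 log units; within the scatter), both lie within the scatter, so no ordering can be read from them; the same holds for a 1.4-fold higher number from compound 1 to compound 2 (0.16 log units; within the scatter). Compound 4 `COc1ccc(C(=O)c2cc(OC)c(OC)c(OC)c2)cc1NC(=O)/C=C/c1ccc([N+](=O)[O-])cc1` carries 4-nitrophenyl in place of 3,4-difluorophenyl on a double-bonded chain carbon bound to a double-bonded chain carbon. Going by the values given here, the steps that bear on this change are the two that already altered the same ring, and neither went beyond the scatter. Changing the groups on that ring has so far moved nothing measurably, so compound 4 is expected to show no step beyond the scatter, a 1.2-fold higher number from compound 3 to compound 4 (0.07 log units; within the scatter). Compound 4 is therefore estimated at 7000 nM in this assay, with a range from 2500 nM to 20000 nM.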

Compound 4, half-maximal inhibitory concentration: 11400 nM
Compound 4: the middle estimate sits 1.6-fold (0.21 log units) below what was measured, and the stated range covers the measured number.
By their numbers in this assay, from the lowest: compounds 3, 1, 4 and 2 (each within the scatter of the next).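

In this assay, 4-nitrophenyl on the double-bonded chain carbon gives a number that cannot be told apart from those of the three earlier arms (a 1.9-fold higher number from compound 3 to compound 4 (0.28 log units; within the scatter)) and (a 1.4-fold higher number from compound 1 to compound 4 (0.14 log units; within the scatter)) and (a 1.0-fold lower number from compound 2 to compound 4 (0.01 log units; within the scatter)). Going by these compounds alone, this extends the earlier picture: the earlier arms carried only fluoro and methoxy groups, whereas this one brings in a nitro group, with nitrogen and oxygen atoms and hydrogen-bond acceptors that 3,4-difluorophenyl lacks, and still no step leaves the scatter. Nothing measured here offers a reason for this flat result.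

On these data alone, all four arms are substituted phenyl rings, so it remains open whether an amine or a carboxylic acid on that ring would produce a step beyond the scatter. Also open, as far as these compounds go, is whether a longer chain would do so, or replacing the phenyl ring with a different ring.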